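Swapping Thiophene for Phenyl on a Nucleoside Core

A few compounds are considered here, and "the series" means these few. Any claim that something is new, unique, unknown or untested is made for them only; others in the source may bear on it.

Of the compounds shown here, three from this series have been tested in a functional assay on HCT-116 cells (Homo sapiens), read by MTT assay, with a stated time of 72 h (a lower number here means a stronger inhibitor, a higher number a weaker inhibitor), and none gave a number. Compound 1, `COc1nc(N)nc2c1c(-c1ccccc1)cn2[C@@H]1O[C@H](CO)[C@@H](O)[C@H]1O`, was reported in this assay as > 20000 nM, which is a limit of the assay rather than a measured value. Compound 3, `C#Cc1cn([C@@H]2O[C@H](CO)[C@@H](O)[C@H]2O)c2ncnc(C)c12`, likewise returned only the limit > 20000 nM in this assay. Compound 2, `O=c1[nH]cnc2c1c(-c1cccs1)cn2[C@@H]1O[C@H](CO)[C@@H](O)[C@H]1O`, stands with them: in this assay it gave > 20000 nM, again a limit and not a number. So compound 2 sits at the top of what the assay can report, as do the other two, which is summed up by the limit of > 20000 nM in this assay, at which 3 of the 3 values shown sit.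

The untested compound 4, `O=c1[nH]cnc2c1c(-c1ccccc1)cn2[C@@H]1O[C@H](CO)[C@@H](O)[C@H]1O`, is built from compound 2 by a single change: phenyl in place of thiophen-2-yl on an aromatic carbon. Among the measured compounds shown here, since no pair of measured compounds differs in one place, there is no measured step to lean on. Every value shown is a limit, and nothing suggests that this change would bring the compound into the range where this assay reports a number. The step from compound 2 to compound 4 is therefore expected to be a step that the limit leaves unreadable from compound 2 to compound 4, that is, none that could be seen. For compound 4 the estimate in this assay is 30000 nM, between 10000 nM and 100000 nM, most likely appearing again only as a limit.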

Compound 4, half-maximal inhibitory concentration: > 100000 nM
Compound 4: only a limit was reported; the forecaster's own chance of this, stated with the estimate: 85%; middle value at least 3.3-fold (0.52 log units) from the limit.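

Compound 2 and compound 4 each appear only as a limit in this assay, and the step between them, phenyl in place of thiophen-2-yl, cannot be read. The compounds shown leave open how much this swap matters and whether any change to the shared core would give a real number in this assay at all.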